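A few compounds are considered here, and "the series" means these few. Any claim that something is new, unique, unknown or untested is made for them only; others in the source may bear on it.

Compound 1 `O=C(Nc1cccc(-n2cc(-c3ccncc3)c(-c3ccc(Cl)c(O)c3)n2)c1)Nc1ccc(Cl)c(Cl)c1` in a functional assay on SK-OV-3 cells (Homo sapiens) for inhibition, read by sulforhodamine B assay, with a stated time of 48 h; a lower number here means that less compound is tolerated, a higher number that more compound is tolerated: > 32500 nM
Compound 2 `COc1cc(-c2nn(-c3cccc(NC(=O)c4cccc(C(F)(F)F)c4)c3)cc2-c2ccncc2)ccc1Cl`: > 50000 nM
Compound 3 `O=C(Nc1cccc(-n2cc(-c3ccncc3)c(-c3ccc(Cl)c(O)c3)n2)c1)Nc1ccc(Cl)c(C(F)(F)F)c1`: > 32500 nM

All three values in this assay are limits of the assay rather than numbers. Compound 1 sits at the limit of > 32500 nM in this assay, at which 2 of the 3 values shown sit, and compound 3 sits there as well. Compound 2 stands at the limit of > 50000 nM in this assay, at which 1 of the 3 values shown sits; in this assay compound 2 gives > 50000 nM, a limit and nothing more. Going by the values given here, the only step among the measured compounds is a step that the two limits leave unreadable from compound 1 to compound 3, and the two limits leave its size unreadable.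

Compound 4 `COc1cc(-c2nn(-c3cccc(NC(=O)Nc4ccc(Cl)c(Cl)c4)c3)cc2-c2ccncc2)ccc1Cl` differs from compound 2 in one place: (3,4-dichlorophenyl)amino in place of 3-(trifluoromethyl)phenyl on a carbonyl carbon. Among the compounds with values here, no measured step follows this particular change. Within the data shown here, compound 1 carries the same (3,4-dichlorophenyl)carbamoyl group on its own core, and in this assay compound 1 gives > 32500 nM; that value is a limit, so it shows only that compound 1 was tolerated up to that point. With every measured compound reaching only a limit, nothing here points to a change beyond the scatter, and the step is expected to be an at least 1.2-fold lower number from compound 2 to compound 4 (0.09 log units; that floor lies within the scatter), most likely ending again at a limit. Compound 4 is therefore estimated at 40000 nM, with a range from 12000 nM to 100000 nM.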

Compound 4, concentration lethal to 50% of the cells: > 50000 nM
Compound 4 was reported as a limit (the forecaster's own chance of this, stated with the estimate: 75%); middle value at least 1.2-fold (0.09 log units) from the limit.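

In this assay compound 4 gives > 50000 nM, a limit of the assay and not a number. Its steps from compound 1 and from compound 2 cannot be read, as both ends of each are limits. The compounds shown leave open where the true value of any of the four compounds lies, and whether any of these changes shifts it at all.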